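The source may report more compounds than this note shows. Statements on the series, on what has been measured and on what is new or still open speak of the compounds shown alone.

Compound 1 `COc1ccc2c(c1)c(CC(=O)NS(=O)(=O)c1ccc(NC3CCCCC3)c([N+](=O)[O-])c1)c(C)n2-c1ccc(-c2ccccc2)cc1` is one of two close analogues examined in an assay on isolated protein for binding affinity to Apoptosis regulator Bcl-2 (Homo sapiens), read by fluorescence polarization, with stated times of 30 min and 20 min; a higher number here means a weaker inhibitor, a lower number a stronger inhibitor. In this assay compound 1 gives > 10000 nM, which is a limit of the assay rather than a number. Compound 2 `COc1ccc2c(c1)c(CC(=O)NS(=O)(=O)c1ccc(NCc3ccccc3)c([N+](=O)[O-])c1)c(C)n2-c1ccc(-c2ccccc2)cc1` carries benzyl in place of cyclohexyl on a nitrogen on an aromatic ring. In this assay compound 2 gives > 10000 nM, again a limit of the assay and not a number. The step that the two limits leave unreadable from compound 1 to compound 2 therefore has no readable size, since both values sit at the limit of > 10000 nM in this assay, at which 2 of the 2 values shown sit. Compound 3 `COc1ccc2c(c1)c(CC(=O)NS(=O)(=O)c1ccc(NCCCc3ccccc3)c([N+](=O)[O-])c1)c(C)n2-c1ccc(-c2ccccc2)cc1` has not yet been measured; it differs from compound 2 by phenethyl in place of phenyl on a saturated chain carbon bound to a nitrogen on an aromatic ring. Going by the values given here, the only measured step bearing on this position, a step that the two limits leave unreadable from compound 1 to compound 2, gives no size or direction to lean on. Compound 3 is therefore expected to remain near the limit, with the step that the limit leaves unreadable from compound 2 to compound 3 estimated to be small. For compound 3 the estimate is 15000 nM, within a range from 3000 nM to 60000 nM.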

Compound 3, inhibition constant: > 10000 nM
Compound 3: no number, only a limit; the forecaster's own chance of this, stated with the estimate: 75%; the middle value lies beyond the limit too.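

No step can be read from compound 1 to compound 3 or from compound 2 to compound 3, since all three compounds stand at one limit: the limit of > 10000 nM in this assay, at which 3 of the 3 values shown sit. The compounds shown leave open how strongly each binds in this assay, and whether the group on the nitrogen changes that binding at all.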